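Imidazolyl for Dimethylamino on the Pyridin-4-yl Core

The source may report more compounds than this note shows. Statements on the series, on what has been measured and on what is new or still open speak of the compounds shown alone.

Of the compounds shown here, three sharing a common scaffold have been measured in a functional assay for inhibition, with Homo sapiens as the target; a lower number here means a stronger inhibitor, a higher number a weaker inhibitor. Compound 1 `CN(C)c1ccc(Nc2nccc(-c3ccccn3)n2)cc1` gives 3300 nM. Compound 2 `c1ccc(-c2ccnc(Nc3ccc(-n4ccnc4)cc3)n2)nc1` differs from compound 1 by 1H-imidazol-1-yl in place of dimethylamino on an aromatic carbon; compound 2 gives 1400 nM, and the step is a 2.4-fold lower number from compound 1 to compound 2 (0.37 log units; beyond the scatter). Compound 3 `CN(C)c1ccc(Nc2nccc(-c3ccncc3)n2)cc1` differs from compound 1 by pyridin-4-yl in place of pyridin-2-yl on an aromatic carbon; compound 3 gives 3700 nM, and the step is a 1.1-fold higher number from compound 1 to compound 3 (0.05 log units; within the scatter), so these two values cannot be told apart here.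

Compound 4 `c1cc(-c2ccnc(Nc3ccc(-n4ccnc4)cc3)n2)ccn1` has not yet been measured in this assay. It differs from compound 3 by 1H-imidazol-1-yl in place of dimethylamino on an aromatic carbon. This is the same kind of change as that from compound 1 to compound 2, and the two places are worded alike, while the two cores differ as described by pyridin-4-yl in place of pyridin-2-yl on an aromatic carbon. For compound 4 the expected step in this assay is a 2.5-fold lower number from compound 3 to compound 4 (0.39 log units; beyond the scatter). Among the measured compounds shown here, this rests on the earlier step of a 2.4-fold lower number from compound 1 to compound 2 (0.37 log units; beyond the scatter), the only other instance of this kind of change, seen on a core that gave a value close to that of compound 3. For compound 4 the value expected in this assay is 1500 nM, within 700 nM to 3500 nM.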

Compound 4, half-maximal inhibitory concentration: 7600 nM
Estimate against measurement, compound 4: 5.1-fold (0.70 log units) below; measured number above the stated range.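

On the core of compound 3, 1H-imidazol-1-yl in place of dimethylamino gives a 2.1-fold higher number from compound 3 to compound 4 (0.31 log units; beyond the scatter) in this assay, the opposite direction to the step on the core of compound 1, so the change did not carry from one core to the other: the same change on two cores in this assay, a 2.4-fold lower number (0.37 log units; beyond the scatter) from compound 1 to compound 2 and a 2.1-fold higher number (0.31 log units; beyond the scatter) from compound 3 to compound 4, 4.8-fold (0.68 log units) apart, beyond the scatter of two such steps. Pyridin-4-yl in place of pyridin-2-yl likewise behaves differently in the two settings, giving a 5.4-fold higher number from compound 2 to compound 4 (0.73 log units; beyond the scatter) where 1H-imidazol-1-yl is present: the same change on two cores in this assay, a 1.1-fold higher number (0.05 log units; within the scatter) from compound 1 to compound 3 and a 5.4-fold higher number (0.73 log units; beyond the scatter) from compound 2 to compound 4, 4.8-fold (0.68 log units) apart, beyond the scatter of two such steps. Among the compounds shown here, the two changes therefore do not add independently across these four compounds, but with only one pair of steps for each change, this does not show why they interact or whether the same reversal would hold beyond this series.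

The compounds shown leave open whether this reversal is particular to 1H-imidazol-1-yl or would also appear with another group on that aromatic carbon, such as a methoxy group or a morpholine. They also leave open how a primary amine at that place would behave on either core.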